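Methyl on the ring nitrogen: compound 3 to compound 4

The compounds below may be only part of what the source reports. "The series", "measured", "known", "first", "only" and "open" are said of these compounds alone.

Measured so far in a functional assay on aorta (Rattus norvegicus, strain Wister); on this read-out lower numbers stand for stronger inhibition and higher numbers for weaker inhibition:
compound 1 `COc1nc(-c2nc3ccccc3n2C)cc(-c2ccccc2)c1C#N`: 300000 nM
compound 2 `COc1nc(-c2nc3ccccc3n2C)cc(-c2ccc(Cl)cc2)c1C#N`: 145000 nM
compound 3 `COc1nc(-c2nc3ccccc3[nH]2)cc(-c2ccc(C)o2)c1C#N`: 202000 nM

Compound 3 stands second highest of the three numbers; its nearest neighbour is compound 2, and both that gap and the gap to compound 1 lie within the scatter, so no order among the three can be read from them. Going by the values given here, the only step in the set is a 2.1-fold lower number from compound 1 to compound 2 (0.32 log units; beyond the scatter), a change on the phenyl ring, which says nothing about the ring nitrogen. Compound 4 `COc1nc(-c2nc3ccccc3n2C)cc(-c2ccc(C)o2)c1C#N` differs from compound 3 by methyl in place of hydrogen on an aromatic nitrogen, on an aromatic nitrogen of a five-membered aromatic ring with 2 nitrogen, part of a fused or bridged system of two rings. Compounds 1 and 2 already carry this methyl, and their numbers sit within the scatter of compound 3, so no step beyond the scatter is expected in this assay. For compound 4 the expected value is 200000 nM, in the range 80000 nM to 450000 nM, meaning an estimated step of a 1.0-fold lower number from compound 3 to compound 4 (0.00 log units; within the scatter).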

Compound 4, half-maximal inhibitory concentration: 283000 nM
Beside the measured number, compound 4's estimate is 1.4-fold (0.15 log units) below it; the measured number falls inside the stated range.
By their numbers in this assay, from the lowest: compounds 2, 3, 4 and 1 (each within the scatter of the next, the first and the last beyond it).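

In this assay, methyl in place of hydrogen on the aromatic nitrogen gives a 1.4-fold higher number from compound 3 to compound 4 (0.15 log units; within the scatter), so this position accepts the methyl without a step beyond the scatter. The methyl also gives the furan-bearing series a direct link to the aryl comparisons: 5-methylfuran-2-yl in place of 4-chlorophenyl gives a 2.0-fold higher number from compound 2 to compound 4 (0.29 log units; within the scatter), and 5-methylfuran-2-yl in place of phenyl gives a 1.1-fold lower number from compound 1 to compound 4 (0.03 log units; within the scatter). Neither replacement separates from the scatter, so at this level of inhibition the aromatic group shows no clear preference between these pairs. No measured evidence bears on the reason for this result.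

Still open, on these data alone, is whether a longer chain on this nitrogen, or one ending in an amine or a carboxylic acid, would produce a step beyond the scatter. As far as these compounds go, the effect of replacing the methoxy or the nitrile on the shared core is also open.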